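The compounds below may be only part of what the source reports. "The series", "measured", "known", "first", "only" and "open" are said of these compounds alone.

Compound 1 `CC(c1ccc(-c2ccccc2)c(F)c1)c1nnc2n1N=C(c1ccc(Cl)cc1)CS2`: 7800 nM
Compound 2 `COc1ccc2cc(C(C)c3nnc4n3N=C(c3ccc(C(F)(F)F)cc3)CS4)ccc2c1`: 10800 nM
Compound 3 `CC(C)Cc1ccc(C(C)c2nnc3n2N=C(c2ccc(Br)cc2)CS3)cc1`: 7100 nM

Of the compounds shown here, three built on one shared core have been tested in a functional assay on HCT-116 cells (Homo sapiens) for inhibition, read by sulforhodamine B assay, with a stated time of 72 h; on this read-out higher numbers stand for weaker inhibition and lower numbers for stronger inhibition. In this assay compound 1 gives 7800 nM, compound 2 gives 10800 nM and compound 3 gives 7100 nM. Compound 1 holds the second highest of the three numbers, yet its nearest neighbour, compound 3, and its furthest, compound 2, both lie within the usual scatter of it, so the three results cannot be told apart and none of them can be called stronger or weaker than another.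

Compound 4 `CC(c1ccc(-c2ccccc2)c(F)c1)c1nnc2n1N=C(c1ccc([N+](=O)[O-])cc1)CS2` has not yet been measured. It differs from compound 1 in a single place: nitro in place of chloro on an aromatic carbon. Going by the values given here, no two of the measured compounds differ from each other in just one place, so there is no measured step of comparable kind to lean on. What the measured set does show is a narrow band of values despite several differences among the three structures.

On that basis the step from compound 1 to compound 4 is expected to be a 1.0-fold higher number from compound 1 to compound 4 (0.01 log units; within the scatter) in this assay, that is, no change beyond the scatter. Compound 4 is therefore estimated at 8000 nM, with a likely range from 3500 nM to 18000 nM.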

Compound 4, half-maximal inhibitory concentration: 7100 nM
The estimate for compound 4 lay 1.1-fold (0.05 log units) above the measured number, and the stated range covers the measured number.
By their numbers in this assay, from the lowest: compounds 3, 4, 1 and 2 (each within the scatter of the next).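

Going by these compounds alone, this is the first pair here that differs in one place only, and in this assay replacing the 4-chlorophenyl group with a 4-nitrophenyl group gives a 1.1-fold lower number from compound 1 to compound 4 (0.04 log units; within the scatter), so the change cannot be told apart from no change at all. At this aromatic carbon, para to a large group, a lone chlorine can therefore give way to a nitro group, with its 3 heavy atoms and 2 hydrogen-bond acceptors, without the read-out moving beyond the scatter. Nothing measured alongside these compounds offers an explanation for this flat result.

A single step at a single place cannot show how far this flatness extends, so an amine or a carboxylic acid on the same aromatic carbon might still shift the number in either direction. On these data alone, it also remains open whether the same swap would stay this small on the rest of compound 2 or compound 3, each of which differs from compound 1 in more than one place.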